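Working notes: replacing the amino side chain of compound 2

This account rests on a few compounds, and the source may have more. Where it says the series, first, only, none or still open, it means among the compounds named here.

Measured in an ADME assay on Vero cells (Chlorocebus sabaeus) for cytotoxicity, with a stated time of 5 days; on this read-out lower numbers stand for stronger inhibition and higher numbers for weaker inhibition:
- Compound 1 `COc1nc(NC2CC2)c2ncn([C@H]3C[C@H](N=[N+]=[N-])[C@@H](CO)O3)c2n1`: > 100000 nM
- Compound 2 `[N-]=[N+]=N[C@H]1C[C@H](n2cnc3c(NCCCCCO)nc(N)nc32)O[C@@H]1CO`: > 100000 nM

Compound 2 gives > 100000 nM, which is a limit of the assay and not a number. The same holds for compound 1, so the record so far is the limit of > 100000 nM in this assay, at which 2 of the 2 values shown sit. Among the measured compounds shown here, no measured pair gives a step to size a structural change.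

Compound 3 `C=CCN(C)c1nc(N)nc2c1ncn2[C@H]1C[C@H](N=[N+]=[N-])[C@@H](CO)O1` carries allyl(methyl)amino in place of (5-hydroxypentyl)amino on an aromatic carbon, next to the ring nitrogen: allyl(methyl)amino in place of (5-hydroxypentyl)amino on an aromatic carbon.

For the measured compounds named here, compound 2 is the only anchor for this change, with its limit of > 100000 nM. No shift beyond the scatter is expected in this assay, and another limit is the likeliest report. Any number reported would be expected toward the lower side, and the expected size is an at least 1.1-fold lower number from compound 2 to compound 3 (0.04 log units; that floor lies within the scatter). For compound 3 the estimated value is 90000 nM, within an expected range of 30000 nM to 100000 nM.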

Compound 3, half-maximal inhibitory concentration: 32000 nM
For compound 3 the middle estimate is 2.8-fold (0.45 log units) above the measured one, and the stated range covers the measured number.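

In this assay, allyl(methyl)amino in place of (5-hydroxypentyl)amino on this aromatic carbon gives an at least 3.1-fold lower number from compound 2 to compound 3 (0.49 log units; beyond the scatter). The side chain at this position can therefore move the read-out from a limit to a number, which neither earlier compound could show, as both stood at a limit: the limit of > 100000 nM in this assay, at which 2 of the 3 values shown sit. The step is a floor and not a full size, as compound 2 gives only a limit.

The change alters several features at once, including chain length, the double bond and the methyl group on the nitrogen, and the compounds shown do not separate their contributions. As far as these compounds go, whether propyl(methyl)amino, with the double bond removed, or a cyclic amine such as morpholine at the same place would give a similar number remains open.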